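Swapping the Thiazole Back for a Sulfonamide

The source may hold more compounds than are shown below. What is called first, only, known or untested is meant among the compounds shown, and "the series" means these compounds.

For the measured compounds named here, compound 2 `c1cc(-c2nccs2)c2c(c1)C(c1ncc[nH]1)CC2` is the only compound of this pair with a number in a functional assay on CHO cells for agonist activity at Alpha-1D adrenergic receptor (Homo sapiens), read by FLIPR and calcium flux (on this read-out lower numbers stand for an effect already at smaller amounts and higher numbers for an effect only at larger amounts of compound), where compound 2 gives 3190 nM. Compound 1 `CS(=O)(=O)Nc1cccc2c1CCC2c1ncc[nH]1` in this assay gives > 10000 nM, which is a limit of the assay rather than a number (the limit of > 10000 nM in this assay, at which 1 of the 2 values shown sits). Compound 3 `CCS(=O)(=O)Nc1cccc2c1CCC2c1ncc[nH]1` differs from compound 2 by (ethylsulfonyl)amino in place of 1,3-thiazol-2-yl on an aromatic carbon. Going by the values given here, the one measured step that bears on this change, an at least 3.1-fold lower number from compound 1 to compound 2 (0.49 log units; beyond the scatter), ran in the opposite direction, so undoing it is expected to give a 3.8-fold higher number from compound 2 to compound 3 (0.58 log units; beyond the scatter). Compound 3 is therefore estimated at 12000 nM, with a range from 4000 nM to 40000 nM, and may again reach only a limit.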

Compound 3, half-maximal effective concentration: > 10000 nM
Compound 3 gave a limit, no number (the forecaster's own chance of this, stated with the estimate: 65%); the middle value does not contradict the limit.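

In this assay, the change gives an at least 3.1-fold higher number from compound 2 to compound 3 (0.49 log units; beyond the scatter), so with a second sulfonamide, (ethylsulfonyl)amino, this aromatic carbon again yields no number, whereas 1,3-thiazol-2-yl does. The step from compound 1 to compound 3, which adds one methyl to the sulfonyl chain, cannot be read, because both values are limits and not numbers: the limit of > 10000 nM in this assay, at which 2 of the 3 values shown sit.

On these data alone, how far the two sulfonamides lie beyond that limit remains open. So does whether an amine or a phenyl ring on this aromatic carbon would give a measurable number, as 1,3-thiazol-2-yl does.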